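The source may hold more compounds than are shown below. What is called first, only, known or untested is meant among the compounds shown, and "the series" means these compounds.

Measured so far:
Compound 1 `CCOc1ccc(-n2nncc2CN2C(=O)C3(C(C#N)=C(N)Oc4c3c3nc5ccccc5nc3c3ccccc43)c3ccccc32)cc1` gives 25200 nM in a functional assay on A549 cells (Homo sapiens) for antiproliferative activity, read by MTT assay, with a stated time of 48 h; a lower number here means a stronger inhibitor, a higher number a weaker inhibitor.
Compound 2 `N#CC1=C(N)Oc2c(N)cc3nc4ccccc4nc3c2C12C(=O)N(Cc1cnnn1-c1ccc(F)cc1)c1ccccc12` gives only a limit in this assay, > 50000 nM.

For the measured compounds named here, compound 2 stands at the limit of this assay and carries no number of its own; it is the one of the two values that sits at that limit (the limit of > 50000 nM in this assay, at which 1 of the 2 values shown sits). Compound 3 `N#CC1=C(N)Oc2c(N)cc3nc4ccccc4nc3c2C12C(=O)N(Cc1cnnn1-c1ccc([N+](=O)[O-])cc1[N+](=O)[O-])c1ccccc12` differs from compound 2 in a single place: 2,4-dinitrophenyl in place of 4-fluorophenyl on an aromatic nitrogen. Going by the values given here, no step between two measured compounds is known, so the size of this change in this assay cannot be read from any measured pair. With compound 2 at the limit, the expected step of an at least 1.2-fold lower number from compound 2 to compound 3 (0.09 log units; that floor lies within the scatter) is an estimate rather than a reading, and a result that again comes back only as a limit is about as likely as a number. Compound 3 is expected to give about 40000 nM, within the range 12000 nM to 100000 nM.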

Compound 3, half-maximal inhibitory concentration: > 50000 nM
Compound 3 was reported as a limit; the forecaster's own chance of this, stated with the estimate: 55%; at least 1.2-fold (0.09 log units) between middle value and limit.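

Compound 2 and compound 3 both come back only as limits, so no step from one to the other can be read: the limit of > 50000 nM in this assay, at which 2 of the 3 values shown sit.

On these data alone, whether 2,4-dinitrophenyl in place of 4-fluorophenyl on an aromatic nitrogen changes the reading at all stays open, and so does the size of any such change.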